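Amide series on a trifluoromethyl aniline core: bromophenyl for cyclohexyl

The source may hold more compounds than are shown below. What is called first, only, known or untested is meant among the compounds shown, and "the series" means these compounds.

Measured so far in a functional assay on NALM-6 cells (Homo sapiens) for cytotoxicity, read by MTT assay, with a stated time of 48 h; a higher number here means a weaker inhibitor, a lower number a stronger inhibitor:
- compound 1 `O=C(Nc1cc(C(F)(F)F)ccc1NC1CCCCC1)c1ccccc1`, "not active" (no number reported)
- compound 2 `O=C(Nc1cc(C(F)(F)F)ccc1NC1CCCCC1)c1cccnc1`, 52300 nM
- compound 3 `O=C(Nc1cc(C(F)(F)F)ccc1NC1CCCCC1)c1ccncc1`, 59000 nM

Among the compounds with values here, compound 2 has the lowest number of the two that were reported in this assay, but the only step known, a 1.1-fold higher number from compound 2 to compound 3 (0.05 log units; within the scatter), lies within the scatter, so compound 2 and compound 3 cannot be ranked against each other. Compound 1 gave no number in this assay and is recorded as not active.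

Compound 4 `O=C(Nc1cc(C(F)(F)F)ccc1Nc1ccc(Br)cc1)c1cccnc1` is not yet measured. It differs from compound 2 at the amine on the aromatic ring: 4-bromophenyl in place of cyclohexyl on a nitrogen on an aromatic ring. Within the data shown here, no measured step touches this position; the single measured step concerns the carbonyl-side ring, not the cyclohexylamino group, so it gives no guidance on size or direction here. Among the measured compounds shown here, the whole series so far sits at high concentrations, and compound 1 shows that a small change elsewhere can remove activity altogether.

With nothing to anchor the change, the expectation for compound 4 is a number near that of compound 2, with a step of a 1.3-fold lower number from compound 2 to compound 4 (0.12 log units; within the scatter), and a broad range. Compound 4 is therefore estimated at 40000 nM in this assay, between 10000 nM and 150000 nM, with a real chance that only a limit is reported.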

Compound 4, half-maximal inhibitory concentration: 17000 nM
Beside the measured number, compound 4's estimate is 2.4-fold (0.37 log units) above it; the range from low to high includes it.
By their numbers in this assay, from the lowest: compound 4; then compounds 2 and 3 (each within the scatter of the next).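

In this assay, the change at the amine gives the only step among the compounds shown that lies beyond the scatter: with 4-bromophenyl in place of cyclohexyl on a nitrogen on an aromatic ring, there is a 3.1-fold lower number from compound 2 to compound 4 (0.49 log units; beyond the scatter) while the rest of the structure stays the same. Within the data shown here, the earlier step, a 1.1-fold higher number from compound 2 to compound 3 (0.05 log units; within the scatter) at the ring on the carbonyl carbon, did not separate its two compounds, so this is the first sign that the number can shift with a single change while a value is retained. The step remains modest, and the number stays high in absolute terms. Nothing available bears on why the number moves at this position, so the step stands as an observation only.

As far as these compounds go, whether the shift belongs to the bromine or to the aromatic ring itself remains open; an unsubstituted phenyl and a 4-chlorophenyl on the same nitrogen would separate the two. Also open, from the compounds shown here alone, is whether the step carries over to the amides of compound 3 and compound 1, and how a morpholine or a longer alkyl chain on that nitrogen would compare.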